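This account rests on a few compounds, and the source may have more. Where it says the series, first, only, none or still open, it means among the compounds named here.

Measured so far:
Compound 1, `CN1CCCN(CCn2ccc3ccc(O)cc32)CC1`: 28%
Compound 2, `C=Cc1ccc2ccn(CCN3CCCN(C)CC3)c2c1`: 79%

In an assay on HEK293 cells for binding affinity to 5-hydroxytryptamine receptor 7 (Homo sapiens), read by radioligand binding, tested at 1 uM (a lower number here means less inhibition, a higher number more inhibition at the concentration tested (going by the name of the read-out)), compound 2 stands highest of the two numbers, with compound 1 as its nearest neighbour, a number 51 percentage points higher from compound 1 to compound 2 (beyond the scatter). Compound 3, `CN1CCCN(CCn2ccc3ccc(C(C)(C)O)cc32)CC1`, has not been measured yet. It differs from compound 2 in one place: 1-hydroxy-1-methylethyl in place of vinyl on an aromatic carbon. For the measured compounds named here, the only step that bears on this is the one from compound 1 to compound 2, where a vinyl group replaced a hydroxy group on the same aromatic carbon and the inhibition rose by a number 51 percentage points higher from compound 1 to compound 2 (beyond the scatter). Compound 3 brings an oxygen bearing a hydrogen back to this position, but wrapped in a larger group that also carries three carbons. A step downward, smaller than that earlier rise, is therefore expected, a number 29 percentage points lower from compound 2 to compound 3 (beyond the scatter). For compound 3 the estimate in this assay is 50%, with a range from 25% to 75%.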

Compound 3, a percentage reported as inhibition, at one concentration (the size of the read-out at that concentration, not a potency): 6%
Estimate against measurement, compound 3: 44 percentage points above; measured number outside the range, below it.
By their numbers in this assay, from the lowest: compound 3; then compound 1; then compound 2.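

In this assay, placing 1-hydroxy-1-methylethyl on this aromatic carbon gives a number 73 percentage points lower from compound 2 to compound 3 (beyond the scatter) and so removes the high inhibition seen with vinyl. The new group also compares poorly with the plain hydroxy group, giving a number 22 percentage points lower from compound 1 to compound 3 (beyond the scatter) and showing that surrounding the hydroxy with extra carbons does not restore inhibition here; among these three compounds, the two with an oxygen on this carbon give the lower numbers. The data offer no measured explanation for this sensitivity.

These compounds leave open whether the drop follows the oxygen and its hydrogen-bond donor, the larger group, or the loss of the double bond. An isopropyl group, which has the same carbon branching without the oxygen, and a methoxy group, which has oxygen without the donor hydrogen, would help separate these possibilities.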